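A Chloro Substituent on the Fused Ring of Compound 3

The compounds below may be only part of what the source reports. "The series", "measured", "known", "first", "only" and "open" are said of these compounds alone.

Compound 3 `COc1ccc(-c2nn(-c3ccccc3)cc2C(=O)Nc2nc3ccccc3s2)cc1` gives 6670 nM in a functional assay on PC-3 cells (Homo sapiens) for cytotoxicity, read by MTT assay, with a stated time of 72 h (on this read-out lower numbers stand for stronger inhibition and higher numbers for weaker inhibition), the second highest of the three numbers shown. Compound 2 `O=C(Nc1nc2ccccc2s1)c1cn(-c2ccccc2)nc1-c1ccc(Cl)cc1` gives 7750 nM, and a 1.2-fold lower number from compound 2 to compound 3 (0.07 log units; within the scatter) lies within the scatter. Among the compounds with values here, compound 1 `O=C(Nc1nc2ccc(Cl)cc2s1)c1cn(-c2ccccc2)nc1-c1ccc(F)cc1` gives 3170 nM, a lower number than compound 3 beyond the scatter, but compound 1 differs from compound 2 in two places, so no single step ties it to the others. Compound 4 `COc1ccc(-c2nn(-c3ccccc3)cc2C(=O)Nc2nc3ccc(Cl)cc3s2)cc1` carries chloro in place of hydrogen on an aromatic carbon, meta to a fused ring and para to a fused ring. Within the data shown here, no measured step isolates this change; the values of compound 1 and compound 2 only suggest that the chloro on the fused ring can go with a lower number. Compound 4 is therefore expected at 4000 nM, between 1500 nM and 10000 nM, and the step of a 1.7-fold lower number from compound 3 to compound 4 (0.22 log units; within the scatter) is estimated to be modest.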

Compound 4, half-maximal inhibitory concentration: 6510 nM
Compound 4: middle estimate off by 1.6-fold (0.21 log units), on the low side; the measured number falls inside the stated range.
By their numbers in this assay, from the lowest: compound 1; then compounds 4, 3 and 2 (each within the scatter of the next).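

In this assay, within the data shown here, the chloro on the fused ring, read alone for the first time, gives a 1.0-fold lower number from compound 3 to compound 4 (0.01 log units; within the scatter), so with methoxy present, 6-chloro-1,3-benzothiazol-2-yl and 1,3-benzothiazol-2-yl cannot be told apart. With that chloro held fixed, the other position gives a 2.1-fold higher number from compound 1 to compound 4 (0.31 log units; beyond the scatter), which is beyond the scatter and ties the lower number of compound 1 to fluoro rather than methoxy in this pair. Nothing available explains this difference. From the compounds shown here alone, what the chloro contributes in compound 1 stays open, as does whether an amine or a carboxylic acid in its place would shift the number.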